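Chloro for difluoromethoxy on the aryl of compound 1

The compounds below may be only part of what the source reports. "The series", "measured", "known", "first", "only" and "open" are said of these compounds alone.

Two compounds of the series have a number in an assay on IMR-32 cells for displacement of a labelled ligand from corticotropin-releasing factor receptor 1 (Homo sapiens), read by scintillation counting, with a stated time of 2 h; a lower number here means a stronger inhibitor, a higher number a weaker inhibitor. Compound 1 `CCc1nc(-c2ccc(OC(F)F)cc2Cl)c(OC)nc1NC(CC)CC` gives 2.5 nM in this assay. Compound 2 `CCc1nc(-c2ccc(OC(C)C)cc2OC)c(CC)nc1NC(CC)CC` gives 4.2 nM in this assay. The two values sit within the usual scatter of each other, so compound 1 merely holds the lower of the two numbers, without a real separation from compound 2; the two compounds also differ in several places at once, so nothing can be read from them about any single change.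

Compound 3 `CCc1nc(-c2ccc(Cl)cc2Cl)c(OC)nc1NC(CC)CC` is not yet measured. It differs from compound 1 in one place: chloro in place of difluoromethoxy on an aromatic carbon. Among the compounds with values here, no pair of measured compounds shows this change, so the size of the step in this assay is unknown. With nothing in the series pointing either way, no step beyond the scatter is expected, and the expected step from compound 1 to compound 3 is set at a 1.2-fold higher number from compound 1 to compound 3 (0.08 log units; within the scatter). Compound 3 is therefore estimated at 3 nM in this assay, within a range of 1 nM to 10 nM.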

Compound 3, inhibition constant: 8 nM
Estimate against measurement, compound 3: 2.7-fold (0.43 log units) below, and the stated range covers the measured number.
By their numbers in this assay, from the lowest: compounds 1, 2 and 3 (each within the scatter of the next, the first and the last beyond it).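

Within the data shown here, the first single-place comparison comes from this assay: chloro in place of difluoromethoxy on the aromatic carbon meta to a chloro group gives a 3.2-fold higher number from compound 1 to compound 3 (0.51 log units; beyond the scatter) and so lies beyond the scatter, though only modestly. This position is therefore not indifferent to its group, yet the smaller chloro, with one heavy atom against four and no hydrogen-bond acceptor, still leaves compound 3 at 8 nM in this assay, so the change costs little and does not abolish binding. Among these compounds, nothing measured so far bears on why the number moves.

This single pair cannot show whether the step would stay the same on another core, and compound 2 differs from both of the others in several places, so it adds nothing on this point. Methoxy, trifluoromethoxy or a plain fluoro on the same carbon would help separate what the oxygen link and the fluorines each contribute to the lower number of compound 1.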